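This account rests on a few compounds, and the source may have more. Where it says the series, first, only, none or still open, it means among the compounds named here.

Working notes, series on the shared core.

Compound 2 `O=C(CN(c1ncnc2c1ncn2C1CCCCO1)C1CC1)NCC(=O)OCc1ccccc1` gives 40.4% in a functional assay on the whole organism (Tail, strain ICR) with Mus musculus as the target, in the tail flick test, with a stated time of 60 min, at a dose of 25 umol/kg by the oral route; on this read-out lower numbers stand for a weaker effect and higher numbers for a stronger effect at the one dose given. Going by the values given here, its only neighbour in the set is compound 1 `NC(=O)CC[C@H](NC(=O)CN(c1ncnc2c1ncn2C1CCCCO1)C1CC1)C(=O)OCc1ccccc1`, which gives 39.4% in this assay; the two numbers cannot be separated, as the step of a number 1 percentage points higher from compound 1 to compound 2 (within the scatter) shows.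

Compound 3 `C[C@@H](O)[C@H](NC(=O)CN(c1ncnc2c1ncn2C1CCCCO1)C1CC1)C(=O)OCc1ccccc1` has not yet been run. It differs from compound 2 by 1-hydroxyethyl in place of hydrogen on a saturated chain carbon bound to an amide-type nitrogen and a carbonyl carbon. Among the compounds with values here, the one measured step that bears on this site is the step of a number 1 percentage points higher from compound 1 to compound 2 (within the scatter), in which a 2-carbamoylethyl group carrying an amide was taken off that same carbon without a change beyond the scatter. Putting a 1-hydroxyethyl group onto that carbon is therefore expected to give a step of about a number 0.4 percentage points lower from compound 2 to compound 3 (within the scatter) in this assay, that is none beyond the scatter. For compound 3 the estimate in this assay is 40%, with a range from 26% to 54%.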

Compound 3, a percentage reported as activity, at one dose (the size of the read-out at that dose, not a potency): 28.4%
Compound 3: middle estimate off by 11.6 percentage points, on the high side, within the range that was stated.
By their numbers in this assay, from the lowest: compound 3; then compounds 1 and 2 (each within the scatter of the next).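

At the saturated chain carbon bound to an amide-type nitrogen and a carbonyl carbon, the substituent can matter in this assay, since 1-hydroxyethyl in place of hydrogen gives a number 12 percentage points lower from compound 2 to compound 3 (beyond the scatter), whereas the step of a number 1 percentage points higher from compound 1 to compound 2 (within the scatter) gave no sign of this. 1-hydroxyethyl in place of 2-carbamoylethyl gives a number 11 percentage points lower from compound 1 to compound 3 (beyond the scatter), so the two groups cannot be treated as interchangeable at this position, even though 2-carbamoylethyl could not be separated from hydrogen. No measurement on these compounds accounts for the difference.

From the compounds shown here alone, with a single 1-hydroxyethyl example, it remains open whether the hydroxyl, the two-carbon skeleton or the defined stereocentre goes with the lower number. Also open, going by these compounds, is how a methyl group, an amine, a carboxylic acid or a longer chain on that carbon would read in this assay.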